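A few compounds are considered here, and "the series" means these few. Any claim that something is new, unique, unknown or untested is made for them only; others in the source may bear on it.

Notes on four compounds sharing one core. Compound 1 `O=C(CN1CCCC1)Nc1ccc2ncnc(Nc3cccc(C(F)(F)F)c3)c2c1` carries a pyrrolidin-1-yl group. In a functional assay on MCF7 cells (Homo sapiens) for antiproliferative activity, read by MTT assay, with a stated time of 48 h (on this read-out lower numbers stand for stronger inhibition and higher numbers for weaker inhibition), compound 1 gives only a limit of the assay, > 100000 nM. Compound 2 `O=C(CN1CCCCC1)Nc1ccc2ncnc(Nc3cccc(C(F)(F)F)c3)c2c1` differs from compound 1 by piperidin-1-yl in place of pyrrolidin-1-yl on a saturated chain carbon bound to a carbonyl carbon. In this assay compound 2 likewise reaches only a limit, > 100000 nM. The resulting step is a step that the two limits leave unreadable from compound 1 to compound 2. Compound 3 `O=C(CN1CCCC1)Nc1ccc2ncnc(Nc3ccc(Cl)c(C(F)(F)F)c3)c2c1` differs from compound 1 by chloro in place of hydrogen on an aromatic carbon. In this assay compound 3 also gives only a limit, > 100000 nM. That step reads a step that the two limits leave unreadable from compound 1 to compound 3. All three values sit at the limit of > 100000 nM in this assay, at which 3 of the 3 values shown sit. Compound 4 `O=C(CN1CCCCC1)Nc1ccc2ncnc(Nc3ccc(Cl)c(C(F)(F)F)c3)c2c1`, not yet measured, differs from compound 3 by piperidin-1-yl in place of pyrrolidin-1-yl on a saturated chain carbon bound to a carbonyl carbon, the same change as made from compound 1 to compound 2, at the same place. The expected step is a step that the limit leaves unreadable from compound 3 to compound 4, resting on a step that the two limits leave unreadable from compound 1 to compound 2 and on (the limit of > 100000 nM in this assay, at which 3 of the 3 values shown sit). For compound 4 the estimate is 200000 nM, within 80000 nM to 1000000 nM, most likely reported again as a limit.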

Compound 4, half-maximal inhibitory concentration: > 100000 nM
Compound 4: no number, only a limit; the forecaster's own chance of this, stated with the estimate: 90%; the middle value does not contradict the limit.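

Compound 4 also gives only a limit, so neither the step to it from compound 3 nor the step to it from compound 2 can be read: the limit of > 100000 nM in this assay, at which 4 of the 4 values shown sit. The compounds shown leave open what size either change has in this assay.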